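A few compounds are considered here, and "the series" means these few. Any claim that something is new, unique, unknown or untested is made for them only; others in the source may bear on it.

Of the compounds shown here, three carrying a furan-3-yl group have been tested in a functional assay on HeLa S3 cells (Homo sapiens) for antiproliferative activity, read by XTT assay, with a stated time of 72 h; a lower number here means a stronger inhibitor, a higher number a weaker inhibitor. Compound 1 `CNc1ncnc2c1c(-c1ccoc1)cn2[C@@H]1O[C@H](CO)[C@@H](O)[C@H]1O` gives > 20000 nM, which is a limit and not a number. Compound 3 `COc1nc(N)nc2c1c(-c1ccoc1)cn2[C@@H]1O[C@H](CO)[C@@H](O)[C@H]1O` gives > 20000 nM, again a limit. Compound 2 `Cc1nc(N)c2c(-c3ccoc3)cn([C@@H]3O[C@H](CO)[C@@H](O)[C@H]3O)c2n1` gives > 20000 nM, also a limit. Compound 2 therefore has no exact place on the scale, and the data amount to the limit of > 20000 nM in this assay, at which 3 of the 3 values shown sit, so no order among the three can be read.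

Compound 4 `Cc1nc(N)c2c(I)cn([C@@H]3O[C@H](CO)[C@@H](O)[C@H]3O)c2n1` keeps all of compound 2 except one group: it has iodo in place of furan-3-yl on an aromatic carbon, (iodo in place of furan-3-yl on an aromatic carbon). Within the data shown here, no measured pair shows what replacing this group does, so any expectation here is loose. Compounds 1, 2 and 3 differ elsewhere on the shared core, yet all keep furan-3-yl, and the group now leaving has not been varied in any measured compound. Some movement toward a stronger inhibitor is therefore conceivable, but a modest one is more likely than a large one, and another reading at the limit is quite possible. The expected size of the change is an at least 1.6-fold lower number from compound 2 to compound 4 (0.22 log units; that floor lies within the scatter). For compound 4 the estimated half-maximal inhibitory concentration is 12000 nM, with an expected range of 2500 nM to 30000 nM.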

Compound 4, half-maximal inhibitory concentration: 4180 nM
For compound 4 the middle estimate is 2.9-fold (0.46 log units) above the measured one; measured number inside the range.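

The earlier compounds shown here all carried furan-3-yl and all sat at one limit, so they could say nothing about this position. In this assay the exchange of furan-3-yl for iodo gives an at least 4.7-fold lower number from compound 2 to compound 4 (0.67 log units; beyond the scatter) and so shows that this aromatic carbon, two ring bonds from the ring nitrogen, is a place where changing the group can move the number toward a stronger inhibitor. On these data alone, the true size of the step is unknown and the printed size is only a floor, because the starting point is a limit and not a number: the limit of > 20000 nM in this assay, at which 3 of the 4 values shown sit.

As far as these compounds go, whether the gain comes from iodo itself or simply from the departure of furan-3-yl stays open, and a bromo atom, an amine or a phenyl ring on this same carbon would help to separate the two. Also open, from the compounds shown here alone, is whether iodo would do the same on the cores of compound 1 and compound 3, which differ from compound 2 elsewhere on the shared core.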